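This account rests on a few compounds, and the source may have more. Where it says the series, first, only, none or still open, it means among the compounds named here.

Measured compounds:
- Compound 1 `O=C(NCc1ccc(F)cc1)c1nc(Br)c2cccnc2c1NCCCNc1c(C(=O)NCc2ccc(F)cc2)nc(Br)c2cccnc12`: > 20000 nM
- Compound 2 `COC(=O)c1nc(Br)c2cccnc2c1N[C@H]1CC[C@H](N)CC1`: "not determined" (no result reported)
- Compound 3 `CNCCCNc1c(C(=O)NCc2ccc(F)cc2)nc(Br)c2cccnc12`: 9000 nM

In a functional assay on HCT-116 cells (Homo sapiens) for cytotoxicity, read by MTT assay, with a stated time of 72 h (on this read-out lower numbers stand for stronger inhibition and higher numbers for weaker inhibition), compound 1 reaches only a limit of the assay, (the limit of > 20000 nM in this assay, at which 1 of the 3 values shown sits), and not a number. Compound 3 in this assay gives 9000 nM. As far as these compounds go, compound 2 stands nowhere on these numbers: no result was reported for it in this assay, so its own potency is unknown.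

Compound 4 `N[C@H]1CC[C@H](Nc2c(C(=O)NC3CCCCC3)nc(Br)c3cccnc23)CC1` differs from compound 2 by cyclohexylamino in place of methoxy on a carbonyl carbon. Among the measured compounds shown here, no measured pair shows this change, so the direction and size of the step cannot be read from the data; with compound 3 as the only numbered relative, a modest value in the weak range is expected. Compound 4 is estimated at 8000 nM, within 2000 nM to 20000 nM.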

Compound 4, half-maximal inhibitory concentration: > 10000 nM
Compound 4: only a limit was reported; the forecaster's own chance of this, stated with the estimate: 30%; middle value at least 1.2-fold (0.09 log units) away from the limit.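

Compound 4 gives only a limit of the assay, > 10000 nM, and not a number. Among the compounds shown here, compound 2 has no number either, so no step between compound 2 and compound 4 can be read. The compounds shown leave open what replacing methoxycarbonyl with cyclohexylcarbamoyl does to potency.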